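The compounds below may be only part of what the source reports. "The series", "measured", "known", "first", "only" and "open" are said of these compounds alone.

Measured so far in the series:

Compound 1, `CCOC(=O)c1ccc(-c2nn(C)c3ccccc23)cc1`: in a functional assay on cells (Platelet, Homo sapiens) for inhibition (a lower number here means a stronger inhibitor, a higher number a weaker inhibitor), compound 1 gives > 10000 nM, which is a limit of the assay and not a number.
Compound 2, `CCOC(=O)c1ccc(-c2nn(CC)c3ccccc23)cc1`: in this assay compound 2 gives > 10000 nM, again a limit.
Compound 3, `CNC(=O)c1ccc(-c2nn(Cc3ccccc3)c3ccccc23)cc1`: in this assay compound 3 gives > 10000 nM, also a limit.

Among the compounds with values here, the one change made twice in this set is methyl in place of hydrogen on a saturated chain carbon bound to an aromatic nitrogen. Between the two measured compounds it gives a step that the two limits leave unreadable from compound 1 to compound 2, so the size of that step cannot be read. The difference between the core of compound 1 and the core of compound 3 is not broken down here.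

Compound 4, `CCNC(=O)c1ccc(-c2nn(Cc3ccccc3)c3ccccc23)cc1`, is not yet measured. It differs from compound 3 by methyl in place of hydrogen on a saturated chain carbon bound to an amide-type nitrogen. The place is not the same as in the earlier pair: there the carbon is bound to an aromatic nitrogen, here to an amide-type nitrogen, so it is the same kind of change rather than the same change.

What the measured values show is the limit of > 10000 nM in this assay, at which 3 of the 3 values shown sit. Within the data shown here, no step in the set has a readable size, so there is nothing to carry over to compound 4 beyond that. The step from compound 3 to compound 4 is expected to be a step that the limit leaves unreadable from compound 3 to compound 4, resting on the three limits. Compound 4 is therefore expected to give 20000 nM in this assay, with an estimated range from 5000 nM to 80000 nM, most probably again reported only as a limit.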

Compound 4, half-maximal inhibitory concentration: > 10000 nM
Compound 4 gave a limit, no number (the forecaster's own chance of this, stated with the estimate: 85%); the middle value is on the limit's open side.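

No new step can be read: compound 3 and compound 4 both return a limit of the assay and not a number, so the methyl to ethyl change on the amide-type nitrogen has no measurable size. The series as a whole stands at one reading: the limit of > 10000 nM in this assay, at which 4 of the 4 values shown sit.

The compounds shown leave open whether any change to this series gives a measurable value in this assay.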